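Indole for fluoromethoxyphenyl on a pyrazolo-fused core

This account rests on a few compounds, and the source may have more. Where it says the series, first, only, none or still open, it means among the compounds named here.

Compound 1: `COc1cc(-c2cc3nccc(-c4c[nH]c5ccccc45)n3n2)cc(OC)c1OC`, > 10000 nM
Compound 2: `COc1ccc(-c2cc3nccc(-c4cc(OC)c(OC)c(OC)c4)n3n2)cc1F`, 3950 nM
Compound 3: `CCOC(=O)c1ccc(-c2cc3nccc(-c4cc(OC)c(OC)c(OC)c4)n3n2)cc1`, > 10000 nM

Of the compounds shown here, three sharing one core have been tested in a functional assay on B16-F0 cells (Mus musculus) for inhibition, read by CCK-8 assay, with a stated time of 48 h; a higher number here means a weaker inhibitor, a lower number a stronger inhibitor. Compound 1 reaches only a limit of the assay, > 10000 nM. Compound 3 likewise gives only a limit, > 10000 nM. Going by the values given here, compound 2, carrying a trimethoxyphenyl group on one side of the core and a 3-fluoro-4-methoxyphenyl group on the other, is the single compound with a measured number, 3950 nM in this assay. Among the compounds with values here, it thus stands alone as the only real value, the other two sitting at the limit (the limit of > 10000 nM in this assay, at which 2 of the 3 values shown sit). Within the data shown here, no two measured compounds differ in just one place, so no measured step is available.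

Compound 4, `COc1cc(-c2ccnc3cc(-c4cn(C)c5ccccc45)nn23)cc(OC)c1OC`, is not yet measured. It keeps the trimethoxyphenyl group of compound 2 and differs from it in one place: 1-methyl-1H-indol-3-yl in place of 3-fluoro-4-methoxyphenyl on an aromatic carbon. Among the measured compounds shown here, with no measured step to lean on, the account expects no change beyond the usual scatter from compound 2 to compound 4, that is a step of a 1.0-fold higher number from compound 2 to compound 4 (0.01 log units; within the scatter) in this assay. Compound 4 is therefore estimated at 4000 nM in this assay, with a broad range from 1000 nM to 16000 nM.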

Compound 4, half-maximal inhibitory concentration: 185 nM
Estimate against measurement, compound 4: 22-fold (1.33 log units) above, and the stated range ends above it.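

Going by these compounds alone, until now no measured step existed, and in this assay the change of 3-fluoro-4-methoxyphenyl to 1-methyl-1H-indol-3-yl on an aromatic carbon of the five-membered ring gives a 21-fold lower number from compound 2 to compound 4 (1.33 log units; beyond the scatter), which shows that this position strongly affects the read-out when the trimethoxyphenyl group stays in place. At the same position, compound 3, which carries a phenyl ring with an ethyl ester, gives only a limit of the assay, > 10000 nM, so the two phenyl-bearing compounds and the indole-bearing compound 4 together show that the group here matters considerably. The data shown give no cause for the size of this step.

The compounds shown leave open whether the methyl group on the indole nitrogen contributes to the result, which an unsubstituted 1H-indol-3-yl group or a longer chain such as ethyl or propyl on that nitrogen at this position would test. They also leave open how far the trimethoxyphenyl group on the other side can be changed, for instance by replacing one of its methoxy groups with a hydroxyl or an amine, while the 1-methyl-1H-indol-3-yl group stays in place.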